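Oxolan-3-yl for oxan-3-yl: a single-place change

The source may report more compounds than this note shows. Statements on the series, on what has been measured and on what is new or still open speak of the compounds shown alone.

Of the compounds shown here, two have numbers so far in a physicochemical assay for solubility, read by chemiluminescence; on this read-out higher numbers stand for higher solubility and lower numbers for lower solubility. Compound 1 `COc1ccc(C(=O)N(Cc2cc(-c3ccccc3)on2)C2CCCCC2)cc1` gives 2 ug/mL, and compound 2 `O=C(CN(C(=O)c1ccc(-c2ccccn2)cc1)C1CCCOC1)Nc1cc(F)cc(F)c1` gives 56 ug/mL. Compound 2 is therefore the higher of the two, with a gap to compound 1 that lies beyond the scatter. These two compounds differ in more than one place, so the gap cannot be assigned to any single group.

The next compound is compound 3 `O=C(CN(C(=O)c1ccc(-c2ccccn2)cc1)C1CCOC1)Nc1cc(F)cc(F)c1`, which departs from compound 2 in one place: oxolan-3-yl in place of oxan-3-yl on an amide-type nitrogen. Both groups are non-aromatic rings with no net charge. For the measured compounds named here, the series holds no measured pair that differs in one place, so there is no direct precedent for this change. In this assay the expectation is therefore no shift beyond the scatter, with no firm direction. The estimated step of a 1.1-fold higher number from compound 2 to compound 3 (0.03 log units; within the scatter) is expected to stay within that scatter. Compound 3 is expected at 60 ug/mL, with an estimated range of 25 ug/mL to 130 ug/mL.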

Compound 3, solubility: 102 ug/mL
Compound 3: middle estimate off by 1.7-fold (0.23 log units), on the low side; the measured number falls inside the stated range.
By their numbers in this assay, from the lowest: compound 1; then compounds 2 and 3 (each within the scatter of the next).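

The series now holds its first pair that differs in one place: in this assay, oxolan-3-yl in place of oxan-3-yl on an amide-type nitrogen gives a 1.8-fold higher number from compound 2 to compound 3 (0.26 log units; within the scatter), so the two compounds cannot be told apart on this read-out. At this position, on a nitrogen whose other neighbours are a carbonyl carbon and a saturated chain carbon, the six-membered non-aromatic ring can thus give way to the five-membered one, with the hydrogen-bond donor and acceptor counts unchanged, and the number stays within the scatter. No separate measurement bears on this pair, and the step has no explanation in the data at hand.

For the compounds shown here, the pair covers only two oxygen-containing rings, so it remains open how this assay responds at this nitrogen to a ring holding an amine, such as piperidin-3-yl, or to an open chain such as 2-methoxyethyl. As far as these compounds go, it also remains open whether the same exchange of oxolan-3-yl for oxan-3-yl reads the same way on a different core, such as the core of compound 1.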